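This account rests on a few compounds, and the source may have more. Where it says the series, first, only, none or still open, it means among the compounds named here.

Three compounds share one core and differ only in the group on the aromatic ring. Compound 1 `Cc1ccc(-c2noc(CCCCCCC(=O)NO)n2)cc1` carries a methyl there, and in an assay on isolated protein for inhibition of histone deacetylase 8 (Homo sapiens), read by fluorescence, with a stated time of 10 min (on this read-out higher numbers stand for weaker inhibition and lower numbers for stronger inhibition), compound 1 gives 5390 nM. Compound 3 `O=C(CCCCCCc1nc(-c2ccc(F)cc2)no1)NO` carries a fluoro, and in this assay compound 3 gives 8760 nM; the step of a 1.6-fold higher number from compound 1 to compound 3 (0.21 log units; within the scatter) lies within the scatter. Compound 2 `O=C(CCCCCCc1nc(-c2ccc(C(F)(F)F)cc2)no1)NO` carries a trifluoromethyl. In this assay compound 2 gives > 10000 nM, which is a limit of the assay and not a number. The steps of an at least 1.8-fold higher number from compound 1 to compound 2 (0.26 log units; that floor lies within the scatter) and an at least 1.1-fold lower number from compound 2 to compound 3 (0.05 log units; that floor lies within the scatter) rest on that limit (the limit of > 10000 nM in this assay, at which 1 of the 3 values shown sits).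

Compound 4 `O=C(CCCCCCc1nc(-c2ccc(C(F)(F)F)cc2)no1)C(F)(F)F` keeps the trifluoromethyl of compound 2 and changes the other end of the chain: trifluoromethyl in place of hydroxyamino on a carbonyl carbon. Going by the values given here, none of the measured steps touches that end; all three move the group on the aromatic ring and none lies beyond the scatter, so they give no measure of this change. Compound 2 sits at the limit, and compound 4 is expected to stay at or beyond it, a step that the limit leaves unreadable from compound 2 to compound 4. The estimate for compound 4 is 20000 nM, ranging from 8000 nM to 60000 nM.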

Compound 4, half-maximal inhibitory concentration: 1030 nM
For compound 4 the middle estimate is 19-fold (1.29 log units) above the measured one; measured number outside the range, below it.
By their numbers in this assay, from the lowest: compound 4; then compounds 1 and 3 (each within the scatter of the next). At a limit, above all of these: compound 2.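

The far end of the chain matters in this assay in a way the changes on the aromatic ring could not show: with trifluoromethyl in place of hydroxyamino on the carbonyl carbon, the result is an at least 9.7-fold lower number from compound 2 to compound 4 (0.98 log units; beyond the scatter). The value of compound 2 is a limit and not a number, so this step is only a floor: the limit of > 10000 nM in this assay, at which 1 of the 4 values shown sits. It is the only step shown that lies beyond the scatter, and it also shows that hydroxyamino at this place is not required for a measurable number in this series.

Going by these compounds, whether the same change gives a similar step with a methyl or a fluoro on the aromatic ring stays open, as it is seen in one pair only. Also open, on these data alone, is how an amine on the carbonyl carbon, or a longer chain, would read.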